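Acetyl in Place of Hydrogen: What Three Numbers Suggest

A few compounds are considered here, and "the series" means these few. Any claim that something is new, unique, unknown or untested is made for them only; others in the source may bear on it.

Three close relatives of one shared core have been tested in a functional assay on KB cells (Homo sapiens) for cytotoxicity; a higher number here means that more compound is needed for the effect, a lower number that less compound is needed. Compound 1 `CCC[C@@H](OC(C)=O)C1=C(Br)/C(=C/Br)OC1=O` gives 2.1 ug/mL. Compound 2 `CCC[C@@H](O)C1=C(Br)/C(=C/I)OC1=O` gives 4.1 ug/mL. Compound 3 `CCC[C@@H](O)C1=C(Br)/C(=C/Cl)OC1=O` gives 1.2 ug/mL. Compound 2 thus carries the highest of the three numbers, yet against compound 1 the two values sit within the usual scatter of repeated measurements, so no order between them can be read; only compound 3 stands apart, with a 3.4-fold lower number from compound 2 to compound 3 (0.53 log units; beyond the scatter).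

Compound 4 `CCC[C@@H](OC(C)=O)C1=C(Br)/C(=C/I)OC1=O` has not yet been measured. It differs from compound 2 in one place: acetyl in place of hydrogen on an oxygen on a saturated carbon

Within the data shown here, no measured step follows this exact change. Compound 1 also carries the acetyl, but it differs from compound 2 in two places at once, so the values of compound 1 and compound 2, which lie within the scatter of each other, only hint that the acetyl does not on its own move the number far. Among the measured compounds shown here, the one measured step, the halogen swap from compound 2 to compound 3, concerns a different part of the molecule and does not bear on this change. The expected step of a 1.2-fold lower number from compound 2 to compound 4 (0.07 log units; within the scatter) in this assay is therefore one within the scatter, in no settled direction. Compound 4 is expected to give about 3.5 ug/mL, with a range from 1.5 ug/mL to 8 ug/mL.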

Compound 4, concentration for half-maximal effect: 3.6 ug/mL
Compound 4: middle estimate off by 1.0-fold (0.01 log units), on the low side; the range from low to high includes it.
By their numbers in this assay, from the lowest: compounds 3, 1, 4 and 2 (each within the scatter of the next, the first and the last beyond it).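

In this assay, the acetyl change now has a direct test that differs in one place only: going from hydroxy to acetoxy on the saturated carbon gives a 1.1-fold lower number from compound 2 to compound 4 (0.06 log units; within the scatter), so with iodo on the double-bonded chain carbon, the free hydroxy and its acetyl form cannot be told apart. The second new comparison separates the halogen from the acetyl, as a 1.7-fold higher number from compound 1 to compound 4 (0.23 log units; within the scatter) shows that bromo and iodo cannot be told apart in this assay when the acetoxy group is present. No measurement is available that would account for either result.

Among these compounds, it remains open whether acetyl in place of hydrogen would also stay within the scatter with chloro or bromo on the double-bonded chain carbon, as the single direct comparison carries iodo. From the compounds shown here alone, it is also open whether a larger group on the same oxygen, such as benzoyl, or a simple methyl ether there would leave the number just as unmoved.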